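Swapping a benzyl thioether for a propyl thioether

The source may hold more compounds than are shown below. What is called first, only, known or untested is meant among the compounds shown, and "the series" means these compounds.

Measured so far:
compound 1 `Cc1cc(N2CC[C@@H](C)[C@@H](N(C)c3ncnc4[nH]ccc34)C2)n2ncnc2n1` — 67400 nM
compound 2 `Cc1cc(N2CC[C@@H](C)[C@@H](N(C)c3ncnc4[nH]ccc34)C2)n2nc(SCc3ccc(F)cc3)nc2n1` — 44300 nM
compound 3 `CCCCCc1c(C)nc2nc(SCc3ccc(Cl)cc3)nn2c1N1CC[C@@H](C)[C@@H](N(C)c2ncnc3[nH]ccc23)C1` — 32300 nM

In a functional assay on BGC-823 cells (Homo sapiens) for inhibition, read by MTT assay, with a stated time of 72 h (a higher number here means a weaker inhibitor, a lower number a stronger inhibitor), compound 2 gives 44300 nM, sitting between compound 1 and compound 3, with both gaps inside the scatter. The unmeasured compound 4 `CCCSc1nc2nc(C)cc(N3CC[C@@H](C)[C@@H](N(C)c4ncnc5[nH]ccc45)C3)n2n1` differs from compound 2 by one change: ethyl in place of 4-fluorophenyl on a saturated chain carbon bound to a sulfur. For the measured compounds named here, the only measured step that touches this position is a 1.5-fold lower number from compound 1 to compound 2 (0.18 log units; within the scatter), which did not move the number beyond the scatter. Compound 3 carries (4-chlorobenzyl)sulfanyl alongside further changes, and its value stays in the same band. With no evidence that this position matters, compound 4 is expected to show a 1.1-fold higher number from compound 2 to compound 4 (0.03 log units; within the scatter), essentially no change. The estimate for compound 4 is 48000 nM, within 20000 nM to 115000 nM.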

Compound 4, half-maximal inhibitory concentration: 51200 nM
Compound 4: the middle estimate sits 1.1-fold (0.03 log units) below what was measured; low and high end bracket the measured number.
By their numbers in this assay, from the lowest: compounds 3, 2, 4 and 1 (each within the scatter of the next, the first and the last beyond it).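

In this assay, ethyl in place of 4-fluorophenyl on a saturated chain carbon bound to a sulfur gives a 1.2-fold higher number from compound 2 to compound 4 (0.06 log units; within the scatter), so this position tolerates losing the aromatic ring without the number leaving the scatter. Propylsulfanyl in place of hydrogen on an aromatic carbon gives a 1.3-fold lower number from compound 1 to compound 4 (0.12 log units; within the scatter), so this simple chain also stays within the scatter of the unsubstituted compound. No supporting data bear on why these numbers stay so close. Still open, going by these compounds, is whether an amine or a carboxylic acid on the sulfur-bound chain would move the number beyond the scatter.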